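Trading a nitrophenyl for a dichlorophenyl: an expected gain

The source may hold more compounds than are shown below. What is called first, only, known or untested is meant among the compounds shown, and "the series" means these compounds.

Compound 1, `CC(C)(C)n1ncc(OCc2nnc(-c3c(F)cccc3F)o2)c(Cl)c1=O`: in a functional assay on the whole organism for inhibition, with Mythimna separata as the target, with a stated time of 5 days (on this read-out higher numbers stand for an effect only at larger amounts of compound and lower numbers for an effect already at smaller amounts), compound 1 gives 45400 nM.
Compound 2, `CC(C)(C)n1ncc(OCc2nnc(-c3ccc([N+](=O)[O-])cc3)o2)c(Cl)c1=O`: in this assay compound 2 gives only a limit, > 299000 nM.

Compound 2 thus stands at the limit of this assay (the limit of > 299000 nM in this assay, at which 1 of the 2 values shown sits), the upper end of the two values shown. Compound 3, `CC(C)(C)n1ncc(OCc2nnc(-c3ccc(Cl)cc3Cl)o2)c(Cl)c1=O`, differs from it by 2,4-dichlorophenyl in place of 4-nitrophenyl on an aromatic carbon. Among the compounds with values here, the one measured step bearing on this exchange is an at least 6.5-fold higher number from compound 1 to compound 2 (0.81 log units; beyond the scatter), which runs the other way, from a halogenated phenyl to the 4-nitrophenyl. A move back to a halogenated phenyl is therefore expected to give a lower number, an at least 4.9-fold lower number from compound 2 to compound 3 (0.69 log units; beyond the scatter), though the limit leaves its size open. Compound 3 is estimated at 60000 nM, within 15000 nM to 299000 nM.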

Compound 3, half-maximal effective concentration: 27800 nM
Beside the measured number, compound 3's estimate is 2.2-fold (0.33 log units) above it; the range from low to high includes it.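

In this assay, 2,4-dichlorophenyl in place of 4-nitrophenyl gives an at least 10-fold lower number from compound 2 to compound 3 (1.03 log units; beyond the scatter), so a second halogenated phenyl at this position also separates clearly from the nitro compound. As far as these compounds go, the value of compound 2 is a limit and not a number, so the true size of that step stays unknown: the limit of > 299000 nM in this assay, at which 1 of the 3 values shown sits. The two halogenated phenyls cannot be told apart, with a 1.6-fold lower number from compound 1 to compound 3 (0.21 log units; within the scatter).

Still open, from the compounds shown here alone, is how an unsubstituted phenyl or a methoxyphenyl would compare here, and so whether the halogens matter or the nitro group alone sets compound 2 apart.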